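This account rests on a few compounds, and the source may have more. Where it says the series, first, only, none or still open, it means among the compounds named here.

Measured so far:
Compound 1, `COC(=O)Nc1cc(-c2ccc(OC[C@@](C)(N)CC(C)C)c(C)c2)ccn1`, gives 0.8 nM.
Compound 2, `Cc1cc(-c2cc(Cl)c(OC[C@@](C)(N)CC(C)C)cn2)ccn1`, gives 1.9 nM.

Both numbers come from an assay on HEK293F cells for inhibition of AP2-associated protein kinase 1 (Homo sapiens), read by Western blot, with a stated time of 3 h; a lower number here means a stronger inhibitor, a higher number a weaker inhibitor. Among these two numbers compound 1 stands lowest, and compound 2 sits at a higher number by a gap that lies beyond the usual scatter of such measurements. Within the data shown here, no single-change step between the two measured compounds is available, so their two values are simply taken as they stand.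

The step under consideration leads from compound 1 to compound 3, `COC(=O)Nc1cc(-c2ccc(OC[C@@](C)(N)CC(C)C)c(C)c2C)ccn1`, which has not yet been measured in this assay. The change is methyl in place of hydrogen on an aromatic carbon. Nothing measured here shows how such a change plays out, so the expectation rests only on the small size of the added group. The expected step is estimated as a 2.5-fold higher number from compound 1 to compound 3 (0.40 log units; beyond the scatter), a modest rise in the number, meaning a slightly weaker inhibitor. A change that stays within the scatter is also possible. Compound 3 is therefore expected to give 2 nM, within a range from 0.6 nM to 7 nM.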

Compound 3, half-maximal inhibitory concentration: 9.7 nM
Estimate against measurement, compound 3: 4.9-fold (0.69 log units) below; the whole stated range lies below it.
By their numbers in this assay, from the lowest: compound 1; then compound 2; then compound 3.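

In this assay, adding one methyl in place of hydrogen gives a 12-fold higher number from compound 1 to compound 3 (1.08 log units; beyond the scatter) and so a clearly weaker inhibitor, a large step for a change of a single heavy atom. This shows that the aromatic carbon, ortho to a large group and ortho to a methyl group, is a sensitive spot in compound 1: even the smallest carbon group placed there costs much of the inhibition. No measurement available here accounts for the size of this loss.

As far as these compounds go, it remains open whether a fluorine atom, a chlorine atom or a methoxy group on this same carbon would bring a similar loss or a smaller one. From the compounds shown here alone, it is also open whether the methyl would have the same effect on a compound that differs from compound 1 elsewhere in its structure.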